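This account rests on a few compounds, and the source may have more. Where it says the series, first, only, none or still open, it means among the compounds named here.

Measured so far:
compound 1, `O=C1c2ccccc2S(=O)(=O)N1CCCCCCN1CCN(c2ccc(Cl)c(Cl)c2)CC1`, 258 nM
compound 2, `O=C1c2ccccc2S(=O)(=O)N1CCCCCCN1CCN(c2ccccc2)CC1`, 192 nM

Both were run in an ADME assay on HEK293 cells for displacement of a labelled ligand from 5-hydroxytryptamine receptor 7 (Homo sapiens), read by radioligand binding, with a stated time of 1 h; a lower number here means a stronger inhibitor, a higher number a weaker inhibitor. Among the measured compounds shown here, compound 2 gives the lower of the two numbers, with compound 1 as its only neighbour, and the gap a 1.3-fold lower number from compound 1 to compound 2 (0.13 log units; within the scatter) sits within the scatter, so the pair cannot be ranked. Compound 3, `O=C1c2ccccc2S(=O)(=O)N1CCCCCCN1CCN(c2cccc3ccccc23)CC1`, differs from compound 2 by naphthalen-1-yl in place of phenyl on an amine nitrogen in a ring. For the measured compounds named here, the single step in hand, a 1.3-fold lower number from compound 1 to compound 2 (0.13 log units; within the scatter), likewise swaps the aryl group on that ring nitrogen and was small; it is the only guide, and a naphthalen-1-yl group has no precedent within the set. The expected step of a 1.3-fold lower number from compound 2 to compound 3 (0.11 log units; within the scatter) in this assay is therefore none beyond the scatter, in either direction, with wide uncertainty. Compound 3 is estimated at 150 nM, with a range from 45 nM to 500 nM.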

Compound 3, inhibition constant: 20 nM
Estimate against measurement, compound 3: 7.5-fold (0.88 log units) above; measured number outside the range, below it.
By their numbers in this assay, from the lowest: compound 3; then compounds 2 and 1 (each within the scatter of the next).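

In this assay, the aryl group on the amine nitrogen of the six-membered non-aromatic ring with 2 nitrogen can move the number well beyond the scatter: naphthalen-1-yl gives a 9.6-fold lower number from compound 2 to compound 3 (0.98 log units; beyond the scatter) and a 13-fold lower number from compound 1 to compound 3 (1.11 log units; beyond the scatter). The earlier swap, a 1.3-fold lower number from compound 1 to compound 2 (0.13 log units; within the scatter), stayed within the scatter, so 3,4-dichlorophenyl and phenyl cannot be ranked, and only naphthalen-1-yl stands apart among the three aryl groups shown. Nothing in hand accounts for this gain.

As far as these compounds go, whether the step depends on the point of attachment remains open, and naphthalen-2-yl on the same nitrogen would address that, while a quinolinyl group would show whether a ring nitrogen is tolerated in the second ring. Also open, from the compounds shown here alone, is whether the step holds with a shorter chain between the shared core and the ring.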